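From compound 3 to a longer carboxy chain

A few compounds are considered here, and "the series" means these few. Any claim that something is new, unique, unknown or untested is made for them only; others in the source may bear on it.

Of the compounds shown here, three sharing one core have been tested in a functional assay on RT16 cells (Cricetulus griseus) for inhibition, read by CellTiter-Blue, with a stated time of 96 h, in the presence of a further agent that is not named here (on this read-out lower numbers stand for stronger inhibition and higher numbers for weaker inhibition), and none of them has yet given a number. Compound 1 (`Nc1nc2[nH]c(CCCCCC(=O)N[C@@H](CCC(=O)O)C(=O)O)cc2c(=O)[nH]1`) gives > 1000 nM as a limit of the assay. Compound 2 (`Nc1nc2[nH]c(CCCCCCC(=O)N[C@@H](CCC(=O)O)C(=O)O)cc2c(=O)[nH]1`) gives > 1000 nM as a limit too. Compound 3 (`Nc1nc2[nH]c(CCCCCC(=O)O)cc2c(=O)[nH]1`) gives > 1000 nM as a limit as well, so it has no exact position of its own on this scale.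

The next compound to be tested is compound 4 (`Nc1nc2[nH]c(CCCCCCCC(=O)O)cc2c(=O)[nH]1`). The change from compound 3 is 2-carboxyethyl in place of carboxy on a saturated chain carbon, five bonds along the chain from an aromatic carbon with 2-carboxyethyl in place of carboxy on a saturated chain carbon, five bonds along the chain from an aromatic carbon.

Going by the values given here, no measured step between two compounds shows what a change of this kind does in this assay and the only guide is the limit of > 1000 nM in this assay, at which 3 of the 3 values shown sit, as the whole of the record so far. With nothing pointing either way, no step beyond the scatter is expected. The estimated step is a step that the limit leaves unreadable from compound 3 to compound 4 and it is expected to have no meaningful direction. For compound 4 the expected value is 1500 nM with an estimated range of 600 nM to 5000 nM although the assay may well report only a limit again.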

Compound 4, half-maximal inhibitory concentration: > 1000 nM
Compound 4: only a limit was reported (the forecaster's own chance of this, stated with the estimate: 80%); the middle value does not contradict the limit.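

Compound 3 and compound 4 both stand only as limits in this assay, so no step can be read between them, and the same holds across the series: the limit of > 1000 nM in this assay, at which 4 of the 4 values shown sit.

The compounds shown leave open whether any of them reaches a measurable value in this assay, and so how the length of the carboxy chain bears on inhibition.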